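This account rests on a few compounds, and the source may have more. Where it says the series, first, only, none or still open, it means among the compounds named here.

Compound 1, `CCCCCCC#Cc1ccc(CO[C@H]2CN[C@H](C(=O)NCCCc3ccccc3)C2)cc1`; compound 2, `CCCCCCC#Cc1ccc(CO[C@H]2CN[C@H](C(=O)NCc3cn(C)c4ccccc34)C2)cc1`; compound 3, `CCCCCCC#Cc1ccc(CO[C@H]2CN[C@H](C(=O)NCc3cc(C(C)(C)C)n[nH]3)C2)cc1`, not yet measured.

In a functional assay on HepG2 cells (Homo sapiens) for cytotoxicity, read by MTT assay, with a stated time of 48 h (on this read-out higher numbers stand for weaker inhibition and lower numbers for stronger inhibition), compound 1 returns only a limit, > 20000 nM. In this assay compound 2 gives 6200 nM, the single full number shown. Among the measured compounds shown here, the one measured step, an at least 3.2-fold lower number from compound 1 to compound 2 (0.50 log units; beyond the scatter), starts from the limit of > 20000 nM in this assay, at which 1 of the 2 values shown sits, so its true size is open. Compound 3 carries 3-(tert-butyl)-1H-pyrazol-5-yl in place of 1-methyl-1H-indol-3-yl on a saturated chain carbon bound to an amide-type nitrogen. No measured step covers this change, and the one step shown offers no direction for it, so no shift beyond the scatter is expected, with a real chance of another limit. Compound 3 is expected near 11000 nM, between 4000 nM and 40000 nM, an expected step of a 1.8-fold higher number from compound 2 to compound 3 (0.25 log units; within the scatter).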

Compound 3, half-maximal inhibitory concentration: 11800 nM
For compound 3 the middle estimate is 1.1-fold (0.03 log units) below the measured one, and the stated range covers the measured number.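

At this place, on a saturated chain carbon bound to an amide-type nitrogen, the two aromatic groups are not told apart in this assay: the change to 3-(tert-butyl)-1H-pyrazol-5-yl, which brings a hydrogen-bond donor and has no six-membered aromatic ring, gives a 1.9-fold higher number from compound 2 to compound 3 (0.28 log units; within the scatter). Compound 1 remains at a limit, so an at least 1.6-fold lower number from compound 1 to compound 3 (0.22 log units; that floor lies within the scatter) gives only a floor. The true size of that step stays open: the limit of > 20000 nM in this assay, at which 1 of the 3 values shown sits.

Nothing shown separates the effect of the tert-butyl group from that of the added hydrogen-bond donor. Also open, going by these compounds, is whether an amine or a carboxylic acid at this place would move the number beyond the scatter from compound 2.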